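The source may report more compounds than this note shows. Statements on the series, on what has been measured and on what is new or still open speak of the compounds shown alone.

In a functional assay on Bel-7402 cells (Homo sapiens) for inhibition, read by MTT assay, with a stated time of 24 h, tested at 0.1 ug/mL (a higher number here means more inhibition of growth at the concentration tested, a lower number less inhibition of growth), compound 1 (`O=C(CCCCC1CCSS1)NO`) gives 10.4%. Compound 2 (`O=C(CCCCC(S)CCS)Nc1cccc(Cl)c1`) gives 3.09% in the same test, within the usual scatter of compound 1, so the two values cannot be told apart. Compound 3 (`Cc1cccc(NC(=O)CCCCC(S)CCS)c1`) differs from compound 2 by methyl in place of chloro on an aromatic carbon. Within the data shown here, no measured pair shows what such a change does, so no shift beyond the scatter is expected in this assay and the expected a number 1.9 percentage points higher from compound 2 to compound 3 (within the scatter) stays small. For compound 3 the estimated value is 5% within an expected range from 0% to 14%.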

Compound 3, percent growth inhibition at one concentration: 10.1%
The estimate for compound 3 lay 5.1 percentage points below the measured number; the measured number falls inside the stated range.
By their numbers in this assay, from the lowest: compounds 2, 3 and 1 (each within the scatter of the next).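

In this assay, among these compounds, methyl in place of chloro on an aromatic carbon, meta to a large group, gives a number 7 percentage points higher from compound 2 to compound 3 (within the scatter) and provides the first matched pair. At this position, exchanging one heavy atom for another therefore leaves the two compounds indistinguishable in growth inhibition. No available evidence bears on the reason for this result. Open, as far as these compounds go, is what an amine or a carboxylic acid on this aromatic carbon would give. Also open, from the compounds shown here alone, is whether any replacement here can produce a step beyond the scatter.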